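A few compounds are considered here, and "the series" means these few. Any claim that something is new, unique, unknown or untested is made for them only; others in the source may bear on it.

Of the compounds shown here, three of one series have been measured in a functional assay on A375P cells (Homo sapiens) for cytotoxicity, read by MTT assay; on this read-out higher numbers stand for weaker inhibition and lower numbers for stronger inhibition. Compound 1 `COC(=O)c1ccc2c(ccn2-c2cccc(NC(=O)Nc3cccc(C(F)(F)F)c3)c2)n1` gives > 10000 nM, which is a limit of the assay and not a number. Compound 2 `COC(=O)c1ccc2c(ccn2-c2cccc(NC(=O)Nc3ccc(Cl)c(C(F)(F)F)c3)c2)n1` gives 9500 nM. The change from compound 2 to compound 1 is hydrogen in place of chloro on an aromatic carbon, and the step it made is an at least 1.0-fold higher number from compound 2 to compound 1 (0.02 log units; that floor lies within the scatter), whose true size is hidden because compound 1 sits at the limit of > 10000 nM in this assay, at which 1 of the 3 values shown sits. Compound 3 `O=C(Nc1ccc(-n2ccc3nc(C(=O)NCc4ccccc4)ccc32)cc1)c1ccc(Cl)c(C(F)(F)F)c1` gives 700 nM; the difference between its core and that of compound 2 is not broken down here. Compound 4 `O=C(Nc1ccc(-n2ccc3nc(C(=O)NCc4ccccc4)ccc32)cc1)c1cccc(C(F)(F)F)c1` is still unmeasured and differs from compound 3 by hydrogen in place of chloro on an aromatic carbon, the same change as from compound 2 to compound 1. The step from compound 3 to compound 4 is expected to be a 1.4-fold higher number from compound 3 to compound 4 (0.15 log units; within the scatter), resting on the measured step of an at least 1.0-fold higher number from compound 2 to compound 1 (0.02 log units; that floor lies within the scatter). Compound 4 is therefore estimated at 1000 nM, most likely between 400 nM and 3000 nM.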

Compound 4, half-maximal inhibitory concentration: 3000 nM
Compound 4: middle estimate off by 3.0-fold (0.48 log units), on the low side; measured number inside the range.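

On the core of compound 3, hydrogen in place of chloro weakens the compound in this assay, with a 4.3-fold higher number from compound 3 to compound 4 (0.63 log units; beyond the scatter). This shows that the chloro group counts on this core, but it does not show whether the change carries over to the core of compound 2 with the same size: the same change on two cores in this assay, an at least 1.0-fold higher number (0.02 log units; that floor lies within the scatter) from compound 2 to compound 1 and a 4.3-fold higher number (0.63 log units; beyond the scatter) from compound 3 to compound 4; the limit leaves it open whether they differ. The earlier step cannot be sized, and the reason lies at its end point: the limit of > 10000 nM in this assay, at which 1 of the 4 values shown sits.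

Still open, as far as these compounds go, is how a fluoro, a methyl or a methoxy group in place of the chloro would read out on either core. Also open, from the compounds shown here alone, is whether any of these would match the chloro group on the core of compound 3.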